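This account rests on a few compounds, and the source may have more. Where it says the series, first, only, none or still open, it means among the compounds named here.

Measured compounds in a functional assay on cells for antagonist activity at C-C chemokine receptor type 4 (Homo sapiens), read by GTPgammaS binding; a lower number here means a stronger inhibitor, a higher number a weaker inhibitor:
Compound 1 `Cn1ncc2c(NS(=O)(=O)c3cccc(Cl)c3Cl)ccnc21` gives 12600 nM.
Compound 2 `COc1nn(C)c2ncnc(NS(=O)(=O)c3cccc(Cl)c3Cl)c12` gives 63.1 nM.
Compound 3 `COCCOc1nn(C)c2ncnc(NS(=O)(=O)c3cccc(Cl)c3Cl)c12` gives 794 nM.

Compound 2 holds the lowest number of the three. The single-point step away from it is a 13-fold higher number from compound 2 to compound 3 (1.10 log units; beyond the scatter), where the added methoxymethyl on the alkoxy side clearly raised the number. Compound 1 differs from compound 2 in more than one place, so its much higher number is taken only as it stands.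

Compound 4 `COc1nn(C2COC2)c2ncnc(NS(=O)(=O)c3cccc(Cl)c3Cl)c12` differs from compound 2 by oxetan-3-yl in place of methyl on an aromatic nitrogen. Within the data shown here, no measured step touches this nitrogen substituent, so the only guide is that enlarging a small group elsewhere on the core, in a 13-fold higher number from compound 2 to compound 3 (1.10 log units; beyond the scatter), cost potency. A loss of moderate size is therefore expected in this assay , a 2.5-fold higher number from compound 2 to compound 4 (0.40 log units; beyond the scatter), and compound 4 is estimated at 160 nM, within 50 nM to 500 nM.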

Compound 4, half-maximal inhibitory concentration: 251 nM
The estimate for compound 4 lay 1.6-fold (0.20 log units) below the measured number, and the stated range covers the measured number.
By their numbers in this assay, from the lowest: compound 2; then compound 4; then compound 3; then compound 1.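

This is the first step shown on the aromatic nitrogen: in this assay, oxetan-3-yl in place of methyl gives a 4.0-fold higher number from compound 2 to compound 4 (0.60 log units; beyond the scatter) as a modest loss. The position therefore responds to this change, though less than the alkoxy side does in the large 13-fold higher number from compound 2 to compound 3 (1.10 log units; beyond the scatter) step. Nothing on hand explains the loss.

The compounds shown leave open whether the loss follows from the ring oxygen or from the larger group as a whole. Cyclobutyl or isopropyl on this nitrogen would separate the two.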